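This account rests on a few compounds, and the source may have more. Where it says the series, first, only, none or still open, it means among the compounds named here.

Compound 3 `C[C@@H](NC(=O)C1(NC(=O)c2cncc(Br)c2)CC1)c1ccc(-n2nc(Cl)c3ccccc32)cc1F` stands highest of the three compounds measured in an in vivo ADME assay on the whole organism (strain Mongrel) for metabolic stability, with Canis familiaris (Canis lupus familiaris) as the target (a lower number here means that the compound disappears faster, a higher number that the compound lasts longer), where compound 3 gives 7.6 h. Its nearest neighbour is compound 1 `C[C@@H](NC(=O)C1(NC(=O)c2ccc(Br)nc2)CC1)c1ccc(-n2nc(Cl)c3ccccc32)cc1F`, which in this assay gives 7.1 h, and the step of a 1.1-fold higher number from compound 1 to compound 3 (0.03 log units; within the scatter). Furthest away is compound 2 `COc1cncc(C(=O)NC2(C(=O)N[C@H](C)c3ccc(-n4nc(Cl)c5ccccc54)cc3F)CC2)c1`, which in this assay gives 2.3 h, so that there is a 3.3-fold higher number from compound 2 to compound 3 (0.52 log units; beyond the scatter).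

Compound 4 `COc1cc(C(=O)NC2(C(=O)N[C@H](C)c3ccc(-n4nc(Cl)c5ccccc54)cc3F)CC2)on1` has not yet been measured in this assay. It differs from compound 3 in one place: 3-methoxy-1,2-oxazol-5-yl in place of 5-bromopyridin-3-yl on a carbonyl carbon. Two of the measured steps bear on this change in that they also set a methoxy against a bromo on the ring attached to the carbonyl carbon: a 3.1-fold lower number from compound 1 to compound 2 (0.49 log units; beyond the scatter), and in the reverse direction a 3.3-fold higher number from compound 2 to compound 3 (0.52 log units; beyond the scatter). Within the data shown here, no measured step exchanges a six-membered aromatic ring with one hetero atom for a five-membered aromatic ring with two hetero atoms, so that part of the change has no precedent among the three compounds, and the estimate is drawn more widely on that account.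

The expected step is therefore a modest fall, a 2.5-fold lower number from compound 3 to compound 4 (0.40 log units; beyond the scatter), in line with the methoxy-bearing compound 2 at 2.3 h. Compound 4 is accordingly estimated at 3 h, within a range from 1.2 h to 8 h.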

Compound 4, half-life: 20.8 h
The estimate for compound 4 lay 6.9-fold (0.84 log units) below the measured number; measured number outside the range, above it.
By their numbers in this assay, from the lowest: compound 2; then compounds 1 and 3 (each within the scatter of the next); then compound 4.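

In this assay the group on the carbonyl carbon proves able to lift the number above both bromopyridine compounds (a 2.7-fold higher number from compound 3 to compound 4 (0.44 log units; beyond the scatter)) and (a 2.9-fold higher number from compound 1 to compound 4 (0.47 log units; beyond the scatter)), so that compound 4 lasts longest of the four. A methoxy group therefore does not go with a lower number in itself: compound 2 carries one and stands lowest, yet keeping a methoxy while 3-methoxy-1,2-oxazol-5-yl enters in place of 5-methoxypyridin-3-yl gives the largest step in the set (a 9.0-fold higher number from compound 2 to compound 4 (0.96 log units; beyond the scatter)). No measurement shown explains this rise.

These compounds do not separate the share of the five-membered ring from that of its methoxy group, since compound 4 is the only one with a 1,2-oxazole ring. A bromo or an amine in place of that methoxy, or a 1,2-oxazol-5-yl ring with no such group, would be needed to tell whether the ring alone holds the higher number, or whether the methoxy group contributes to it.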